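The compounds below may be only part of what the source reports. "The series", "measured", "known", "first", "only" and "open" are said of these compounds alone.

Working notes on the series in an in vitro ADME assay on microsomes from liver (Homo sapiens) for pharmacokinetics, read by LC-MS, with a stated time of 10 min, tested at 1 uM; a higher number here means faster removal of the compound, a lower number slower removal. Compound 1 `CN1C[C@H](C(=O)Nc2ccccc2)[C@@H](c2ccc(/C=C/C(=O)Nc3ccccc3N)cc2)C1` gives 7 mL/min/kg, compound 2 `CN1C[C@H](C(=O)Nc2cccc(F)c2)[C@@H](c2ccc(/C=C/C(=O)Nc3ccccc3N)cc2)C1` gives 6 mL/min/kg, and compound 3 `CN1C[C@H](C(=O)Nc2ccc(Cl)cc2F)[C@@H](c2ccc(/C=C/C(=O)Nc3ccccc3N)cc2)C1` gives 11 mL/min/kg. These three numbers lie within the scatter of one another, so compound 3 does not stand apart from compound 1 or compound 2.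

Compound 4 `CN1C[C@H](C(=O)N2CCCCC2)[C@@H](c2ccc(/C=C/C(=O)Nc3ccccc3N)cc2)C1` carries a larger change: piperidin-1-yl in place of (4-chloro-2-fluorophenyl)amino on a carbonyl carbon. The (4-chloro-2-fluorophenyl)carbamoyl of compound 3 thus becomes (piperidin-1-yl)carbonyl.

The measured steps bear on this only indirectly. They are a 1.2-fold lower number from compound 1 to compound 2 (0.07 log units; within the scatter), a 1.6-fold higher number from compound 1 to compound 3 (0.20 log units; within the scatter) and a 1.8-fold higher number from compound 2 to compound 3 (0.26 log units; within the scatter), all within the scatter, and every compound behind them keeps an aromatic ring on the amide-type nitrogen. Going by the values given here, no measured compound shows what replacing that ring does, so the direction remains open.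

The expectation therefore starts from compound 3 at 11 mL/min/kg and foresees no move beyond the scatter, with an estimated 1.2-fold lower number from compound 3 to compound 4 (0.09 log units; within the scatter). Compound 4 is expected at 9 mL/min/kg, with an estimated range of 4 mL/min/kg to 22 mL/min/kg.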

Compound 4, clearance: 9 mL/min/kg
Estimate against measurement, compound 4: no gap at the digits printed; the measured number falls inside the stated range.
By their numbers in this assay, from the lowest: compounds 2, 1, 4 and 3 (each within the scatter of the next).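

In this assay, piperidin-1-yl in place of the aromatic amine groups gives a 1.2-fold lower number from compound 3 to compound 4 (0.09 log units; within the scatter), a 1.5-fold higher number from compound 2 to compound 4 (0.18 log units; within the scatter) and a 1.3-fold higher number from compound 1 to compound 4 (0.11 log units; within the scatter). Going by these compounds alone, at this carbonyl carbon, therefore, both the aromatic ring and the amide hydrogen can be replaced without a move beyond the scatter, which the earlier compounds could not show because all of them keep both features. Nothing available bears on the reason for this result.

From the compounds shown here alone, it remains open whether morpholin-4-yl, with a second hetero atom in the ring, or open-chain diethylamino on the same carbonyl carbon would also stay within the scatter of these values. Going by these compounds, it is also open whether piperidin-1-yl would behave in the same way on any core other than the shared core.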